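Aromatic group swap in a series resting on its limit

The source may report more compounds than this note shows. Statements on the series, on what has been measured and on what is new or still open speak of the compounds shown alone.

Measured in a functional assay on HOS cells (Homo sapiens) for antiproliferative activity, with a stated time of 72 h (on this read-out lower numbers stand for stronger inhibition and higher numbers for weaker inhibition), each value a limit:
compound 1 `OC[C@H]1O[C@@H](n2cnc3c(NCc4ccccc4F)ncnc32)[C@H](O)[C@@H]1O` gives > 166000 nM
compound 2 `COc1ccccc1CNc1ncnc2c1ncn2[C@@H]1O[C@H](CO)[C@@H](O)[C@H]1O` gives > 166000 nM
compound 3 `OC[C@H]1O[C@@H](n2cnc3c(NCc4ccc(F)c(Cl)c4)ncnc32)[C@H](O)[C@@H]1O` gives > 166000 nM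

Compound 3 stands only at a limit, > 166000 nM, and has no number.

Compound 4 `Cc1cccc(CNc2ncnc3c2ncn3[C@@H]2O[C@H](CO)[C@@H](O)[C@H]2O)c1O` differs from compound 3 by one change: 2-hydroxy-3-methylphenyl in place of 3-chloro-4-fluorophenyl on a saturated chain carbon bound to a nitrogen on an aromatic ring, that is, 2-hydroxy-3-methylphenyl in place of 3-chloro-4-fluorophenyl.

Three measured steps changed this same group: a step that the two limits leave unreadable from compound 1 to compound 3, a step that the two limits leave unreadable from compound 2 to compound 3 and a step that the two limits leave unreadable from compound 1 to compound 2. None has a readable size, and the series shows (the limit of > 166000 nM in this assay, at which 3 of the 3 values shown sit). No step beyond the scatter is therefore expected in this assay, and no direction can be given.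

The expected change is a step that the limit leaves unreadable from compound 3 to compound 4.

Compound 4 is estimated at 170000 nM, within 80000 nM to 350000 nM, and will probably be reported only as a limit.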

Compound 4, half-maximal inhibitory concentration: > 166000 nM
Compound 4: only a limit was reported; the forecaster's own chance of this, stated with the estimate: 88%; the middle value is on the limit's open side.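

No new step can be read between compound 4 and compound 1, compound 2 or compound 3, since the series rests on one limit: the limit of > 166000 nM in this assay, at which 4 of the 4 values shown sit.

The compounds shown leave open whether any change to this group on the shared core would give a readable number in this assay.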